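Swapping the aryl ring on a chromene chalcone core

A few compounds are considered here, and "the series" means these few. Any claim that something is new, unique, unknown or untested is made for them only; others in the source may bear on it.

Measured so far in a functional assay on HepG2 cells (Homo sapiens) for antiproliferative activity, read by MTT assay, with a stated time of 24 h; on this read-out lower numbers stand for stronger inhibition and higher numbers for weaker inhibition:
compound 1 `COc1ccc(C(=O)/C=C/c2cccc(F)c2)c2c1C=CC(C)(C)O2`: > 10000 nM
compound 2 `COc1ccc(C(=O)/C=C/c2ccc(N(C)C)cc2)c2c1C=CC(C)(C)O2`: 730 nM
compound 3 `COc1ccc(C(=O)/C=C/c2ccco2)c2c1C=CC(C)(C)O2`: > 10000 nM

Compound 1 sits at the limit of > 10000 nM in this assay, at which 2 of the 3 values shown sit, which is a limit of the assay and not a number. Compound 3 also sits at that limit. Only compound 2 gives a number, and the step of an at least 13-fold lower number from compound 1 to compound 2 (1.13 log units; beyond the scatter) shows how far a change of the aryl ring can move this read-out, while a step that the two limits leave unreadable from compound 1 to compound 3 remains unreadable.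

Compound 4 `COc1ccc(C(=O)/C=C/c2ccc(O)cc2)c2c1C=CC(C)(C)O2` differs from compound 1 by 4-hydroxyphenyl in place of 3-fluorophenyl on a double-bonded chain carbon bound to a double-bonded chain carbon. The 4-hydroxyphenyl group resembles the 4-(dimethylamino)phenyl of compound 2 more than the furan-2-yl of compound 3, so some move toward a readable number is expected, though smaller than that step. For compound 4 the estimate is 3000 nM, between 700 nM and 15000 nM, meaning an expected step of an at least 3.3-fold lower number from compound 1 to compound 4 (0.52 log units; beyond the scatter).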

Compound 4, half-maximal inhibitory concentration: > 10000 nM
Compound 4 gave a limit, no number; the forecaster's own chance of this, stated with the estimate: 35%; middle value at least 3.3-fold (0.52 log units) away from the limit.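

Compound 4 also gives a limit of the assay, not a number: the limit of > 10000 nM in this assay, at which 3 of the 4 values shown sit. Hydroxy in place of dimethylamino on an aromatic carbon gives an at least 13-fold higher number from compound 2 to compound 4 (1.13 log units; beyond the scatter) in this assay, so the readable value of compound 2 does not carry over to this 4-hydroxyphenyl analogue. The steps to compound 4 from compound 1 and from compound 3 cannot be read, as both ends are limits.

Among the compounds shown here, compound 2 remains the only one with a number, so it is open whether this depends on dimethylamino specifically. An unsubstituted amine or a diethylamino group on the same aromatic carbon would test this.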